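An Amino Group in Place of a Methoxy Group

The compounds below may be only part of what the source reports. "The series", "measured", "known", "first", "only" and "open" are said of these compounds alone.

Compound 1 `COc1cccc(C(=O)Nc2cccc(C(=O)O/N=C3\CCCc4onc(-c5ccc(OC)c(OC)c5)c43)c2)c1` carries a methoxy group on the outer benzamide ring of the shared core. In a functional assay on MDA-MB-231 cells (Homo sapiens) for antiproliferative activity, read by MTT assay, with a stated time of 72 h (on this read-out lower numbers stand for stronger inhibition and higher numbers for weaker inhibition), compound 1 gives > 25000 nM, which is a limit of the assay and not a number. Compound 2 `CC(C)(C)OC(=O)Nc1cccc(C(=O)Nc2cccc(C(=O)O/N=C3\CCCc4onc(-c5ccc(F)cc5)c43)c2)c1` is the second measured member of the set. In this assay compound 2 gives > 25000 nM, again a limit rather than a number. Both values sit at the limit of > 25000 nM in this assay, at which 2 of the 2 values shown sit, so compound 1 stands where every measured compound stands, with no number to rank it against another. Compound 3 `COc1ccc(-c2noc3c2/C(=N/OC(=O)c2cccc(NC(=O)c4cccc(N)c4)c2)CCC3)cc1OC` has not yet been measured in this assay; it differs from compound 1 by amino in place of methoxy on an aromatic carbon. Among the measured compounds shown here, no step between measured compounds is known, so no measured change gives a direction for this swap. With both measured compounds at the limit, no shift beyond the scatter is expected, and a reported limit remains the most likely outcome for compound 3. The estimated step is a step that the limit leaves unreadable from compound 1 to compound 3, expected to lie within the scatter. Compound 3 is expected to give about 30000 nM, within a range from 8000 nM to 100000 nM.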

Compound 3, half-maximal inhibitory concentration: > 25000 nM
Compound 3 gave a limit, no number; the forecaster's own chance of this, stated with the estimate: 80%; the middle value lies beyond the limit too.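

In this assay compound 3 gives > 25000 nM, a limit of the assay and not a number. Among the compounds shown here, compound 1 also stands at a limit, so no step from compound 1 to compound 3 can be read: the limit of > 25000 nM in this assay, at which 3 of the 3 values shown sit. The compounds shown leave open whether amino in place of methoxy changes activity in this assay at all.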